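Hydroxy to chloro on the aryl ketone of the series

This account rests on a few compounds, and the source may have more. Where it says the series, first, only, none or still open, it means among the compounds named here.

The series shares one core, seen in compound 1 `COc1ccc(C(=O)/C=C/c2cc3ccccc3[nH]c2=O)cc1` and compound 2 `O=C(/C=C/c1cc2ccccc2[nH]c1=O)c1ccc(O)cc1`. In a functional assay on MDA-MB-435 cells (Homo sapiens) for cytotoxicity, read by sulforhodamine B assay, with a stated time of 24 h (a lower number here means a stronger inhibitor of growth, a higher number a weaker inhibitor of growth), compound 1 gives 17400 nM, and compound 2 gives 16800 nM. Within the data shown here, the single measured step, a 1.0-fold lower number from compound 1 to compound 2 (0.02 log units; within the scatter), is hydrogen in place of methyl on an oxygen on an aromatic ring. Compound 2 thus holds the smaller of the two numbers, but its gap to compound 1 lies within the scatter, so the two stand as equals on the evidence so far.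

Compound 3 `O=C(/C=C/c1cc2ccccc2[nH]c1=O)c1ccc(Cl)cc1` is the next member. It differs from compound 2 by chloro in place of hydroxy on an aromatic carbon of a six-membered aromatic ring of carbon only, para to a large group; cut one bond further out it reads 4-hydroxyphenyl to 4-chlorophenyl. Among the measured compounds shown here, no measured step exchanges hydroxy for chloro. For the measured compounds named here, the only step touching that ring, a 1.0-fold lower number from compound 1 to compound 2 (0.02 log units; within the scatter), stayed within the scatter, which hints that the ring tolerates exchange there without moving the number. The step to compound 3 is therefore expected to be small, a 1.1-fold lower number from compound 2 to compound 3 (0.05 log units; within the scatter), with no sure direction. Compound 3 is estimated at 15000 nM in this assay, between 5000 nM and 45000 nM.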

Compound 3, concentration for total growth inhibition: 13100 nM
The estimate for compound 3 lay 1.1-fold (0.06 log units) above the measured number; the range from low to high includes it.
By their numbers in this assay, from the lowest: compounds 3, 2 and 1 (each within the scatter of the next).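

In this assay, the step of a 1.3-fold lower number from compound 2 to compound 3 (0.11 log units; within the scatter) exchanges hydroxy, with 1 hydrogen-bond donor and 1 hydrogen-bond acceptor, for chloro, with 0 of each, so removing both counts at this aromatic carbon, para to a large group, leaves the two compounds indistinguishable. Among these compounds, the step of a 1.3-fold lower number from compound 1 to compound 3 (0.12 log units; within the scatter) reads the same way and extends the comparison to methoxy, so that hydroxy, methoxy and chloro at this place form a set of three with no order that the read-out can support, where the earlier pair offered only two groups on oxygen. No measurement available here bears on why these three compounds stand together.

Still open, on these data alone, is whether any group at this place can separate from the set beyond the scatter, for instance an amine, a carboxylic acid or a longer chain such as butoxy. The compounds shown also vary only this one place, so they leave open how the number responds to changes elsewhere on the shared core, including the amide hydrogen and the carbonyl of the linking chain.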